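The compounds below may be only part of what the source reports. "The series", "measured", "known", "first", "only" and "open" are said of these compounds alone.

Compound 1 `COc1ccc(/C=C/C(=O)Nc2cc3c(Nc4ccc(F)c(Cl)c4)ncnc3cc2OC)cc1` is reported in a functional assay on A549 cells (Homo sapiens) for cytotoxicity, read by MTT assay, with a stated time of 72 h (on this read-out higher numbers stand for weaker inhibition and lower numbers for stronger inhibition), as "not active" (no number reported), so no single number marks where it stands. Its companion compound 2 `COc1cc2ncnc(Nc3ccc(F)c(Cl)c3)c2cc1NC(=O)/C=C/c1ccccc1[N+](=O)[O-]` gives 33300 nM in this assay. Compound 3 `COc1ccc(/C=C/C(=O)Nc2cc3c(Nc4ccc(F)c(Cl)c4)ncnc3cc2O[C@H]2CCOC2)cc1` differs from compound 1 in one place: oxolan-3-yl in place of methyl on an oxygen on an aromatic ring. Among the measured compounds shown here, no measured step accompanies this change, so the expected shift in this assay is small, likely within the scatter, with weak inhibition remaining the probable outcome. Compound 3 is therefore expected to give about 40000 nM, with a plausible span from 15000 nM to 100000 nM, and a fair chance that only a limit is reported.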

Compound 3, half-maximal inhibitory concentration: 3050 nM
Estimate against measurement, compound 3: 13-fold (1.12 log units) above; measured number outside the range, below it.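

In this assay, among the compounds shown here, compound 1 is recorded as "not active" (no number reported) while compound 3 gives 3050 nM and no step between them can be read. What the change from methoxy to (oxolan-3-yl)oxy contributes stays open, and nothing shown bears on a cause.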